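Aryl variation on the shared core

This account rests on a few compounds, and the source may have more. Where it says the series, first, only, none or still open, it means among the compounds named here.

For the measured compounds named here, compound 2 `Cn1c(=O)c(=O)n(C2CCCC2)c2nc(N/N=C/c3cccs3)ncc21` gives 75600 nM in a functional assay on PC-3 cells (Homo sapiens) for antiproliferative activity, read by MTT assay (a higher number here means a weaker inhibitor, a lower number a stronger inhibitor), the highest of the two numbers measured so far; compound 1 `COc1cccc(/C=N/Nc2ncc3c(n2)n(C2CCCC2)c(=O)c(=O)n3C)c1` gives 20700 nM. Going by the values given here, the single measured step, a 3.7-fold higher number from compound 1 to compound 2 (0.56 log units; beyond the scatter), is modest. Compound 3 `Cn1c(=O)c(=O)n(C2CCCC2)c2nc(N/N=C/c3ccc(F)cc3F)ncc21` carries the change (2,4-difluorophenyl in place of thiophen-2-yl on a carbon with a double bond to nitrogen). This change brings back a six-membered aromatic ring of carbon only, as in compound 1, so the step in this assay is expected to run opposite to the measured one, lowering the number. The expected step is a 2.5-fold lower number from compound 2 to compound 3 (0.40 log units; beyond the scatter). Compound 3 is therefore estimated at 30000 nM, with a range from 10000 nM to 90000 nM.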

Compound 3, half-maximal inhibitory concentration: 13200 nM
For compound 3 the middle estimate is 2.3-fold (0.36 log units) above the measured one; measured number inside the range.
By their numbers in this assay, from the lowest: compounds 3 and 1 (each within the scatter of the next); then compound 2.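

In this assay the change gives a 5.7-fold lower number from compound 2 to compound 3 (0.76 log units; beyond the scatter) and, with the earlier step, leaves thiophen-2-yl with the highest number of the three, beyond the scatter against both six-membered aromatic rings of carbon only. The two such rings cannot be told apart here, since the change gives a 1.6-fold lower number from compound 1 to compound 3 (0.20 log units; within the scatter) and 2,4-difluorophenyl and 3-methoxyphenyl therefore read alike on this carbon. No measurement at hand explains these steps. On these data alone, whether a furan-2-yl group would follow thiophen-2-yl stays open, as does the outcome of an amine or a carboxylic acid on the phenyl ring.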